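The source may report more compounds than this note shows. Statements on the series, on what has been measured and on what is new or still open speak of the compounds shown alone.

Working notes on the series

The three compounds share one core and differ only in the group on one aromatic carbon. Compound 1 `Cc1cc(-c2ccco2)c2ncc(CSCCc3ccccc3)n2c1` carries furan-2-yl there, and in an ADME assay on HEL cells (Homo sapiens) for cytotoxicity, with a stated time of 3 days (on this read-out higher numbers stand for lower toxicity in this test and lower numbers for higher toxicity in this test), compound 1 gives 41 ug/mL. Compound 2 `Cc1cc(C#N)c2ncc(CSCCc3ccccc3)n2c1` carries cyano on the same carbon. In this assay compound 2 reaches only a limit of the test, > 100 ug/mL, so no number is known for it. Compound 2 thus sits at the limit of > 100 ug/mL in this assay, at which 1 of the 2 values shown sits. The step of an at least 2.4-fold higher number from compound 1 to compound 2 (0.38 log units; beyond the scatter) is accordingly a lower bound for the rise.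

Compound 3 `Cc1cc(Sc2ccc(Cl)cc2)c2ncc(CSCCc3ccccc3)n2c1` is not yet measured; it differs from compound 2 by (4-chlorophenyl)sulfanyl in place of cyano on an aromatic carbon. Going by the values given here, one measured step bears on this change, an at least 2.4-fold higher number from compound 1 to compound 2 (0.38 log units; beyond the scatter), in which an aromatic ring gave way to cyano and the number rose. The change to compound 3 runs the other way, cyano giving way to a group that holds a six-membered aromatic ring, so a fall in this assay is expected, an at least 3.3-fold lower number from compound 2 to compound 3 (0.52 log units; beyond the scatter). Compound 3 is estimated at 30 ug/mL, with a range of 10 ug/mL to 100 ug/mL. A number rather than a limit is expected for compound 3, though the limit of compound 2 leaves the size of the fall open.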

Compound 3, half-maximal cytotoxic concentration: 100 ug/mL
Beside the measured number, compound 3's estimate is 3.3-fold (0.52 log units) below it; the measured number falls inside the stated range.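

Working from the one earlier step, compound 1 to compound 2, an aromatic ring in the group on this carbon might have seemed enough to bring the number down, but compound 3 goes against that reading. With (4-chlorophenyl)sulfanyl in place of furan-2-yl, this assay shows a 2.4-fold higher number from compound 1 to compound 3 (0.39 log units; beyond the scatter), a modest step, so a six-membered aromatic ring held through sulfur does not go with the lower number seen for compound 1. The change from cyano to (4-chlorophenyl)sulfanyl gives a number no higher from compound 2 to compound 3 (the limit leaves the size open). The size of that step cannot be read, because compound 2 stands at a limit of the test: the limit of > 100 ug/mL in this assay, at which 1 of the 3 values shown sits.

The compounds shown do not separate the sulfur from the 4-chlorophenyl ring in compound 3, so it stays open which part of that group goes with its number. Going by these compounds, how an amine, a carboxylic acid or a simple phenyl on this aromatic carbon would read in this assay also stays open.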